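This account rests on a few compounds, and the source may have more. Where it says the series, first, only, none or still open, it means among the compounds named here.

In an ADME assay on HaCaT cells (Homo sapiens) for cytotoxicity, read by MTT assay, with a stated time of 72 h (a higher number here means a weaker inhibitor, a lower number a stronger inhibitor), compound 1 `CCNC1=CC(=O)C(C(C)(C)C)=CC1=O` gives 75000 nM and compound 2 `CC(C)(C)C1=CC(=O)C(NCc2ccccc2)=CC1=O` gives 28000 nM, which is a 2.7-fold lower number from compound 1 to compound 2 (0.43 log units; beyond the scatter). Compound 3 `CCCCNC1=CC(=O)C(C(C)(C)C)=CC1=O` gives > 100000 nM, and this is a limit of the assay, not a number. Compound 3 therefore stands at the limit of > 100000 nM in this assay, at which 1 of the 3 values shown sits.

Compound 4 `CCCCCCCCNC1=CC(=O)C(C(C)(C)C)=CC1=O` keeps the shared core and lengthens the chain of compound 3. The change is butyl in place of hydrogen on a saturated chain carbon, four bonds along the chain from an amine nitrogen.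

For the measured compounds named here, the nearest precedent is also a chain extension, an at least 1.3-fold higher number from compound 1 to compound 3 (0.12 log units; that floor lies within the scatter). Going by these compounds, since that figure is only a floor, the true size of this step remains unknown. The other steps involve a phenyl group rather than a longer chain: a 2.7-fold lower number from compound 1 to compound 2 (0.43 log units; beyond the scatter) and an at least 3.5-fold higher number from compound 2 to compound 3 (0.55 log units; beyond the scatter). They show that the side chain can move the number, but neither one tests a chain as long as that of compound 4.

With so little to go on, a modest move to a lower number is expected, although compound 4 may also remain at the limit. The expected step is an at least 1.6-fold lower number from compound 3 to compound 4 (0.22 log units; that floor lies within the scatter). Compound 4 is estimated at 60000 nM, within an expected range of 15000 nM to 150000 nM.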

Compound 4, half-maximal inhibitory concentration: > 100000 nM
Compound 4 ended at the assay's limit (the forecaster's own chance of this, stated with the estimate: 30%); middle value at least 1.6-fold (0.22 log units) from the limit.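

In this assay the value of compound 4 is a limit of the assay and not a number, the same limit that compound 3 reaches, so the step between them cannot be read: the limit of > 100000 nM in this assay, at which 2 of the 4 values shown sit.

What is new is that butyl in place of hydrogen, four bonds along the chain from an amine nitrogen, does not bring the number down to a readable value, so the longer chain gives no sign of a stronger effect on these cells. The two remaining steps are floors: an at least 3.5-fold higher number from compound 2 to compound 4 (0.55 log units; beyond the scatter) shows that compound 4 stands clearly apart from the phenyl-bearing compound 2, while an at least 1.3-fold higher number from compound 1 to compound 4 (0.12 log units; that floor lies within the scatter) leaves compound 4 and compound 1 without a firm order.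

Going by these compounds, whether lengthening the chain changes the true value at all stays open, since neither compound 3 nor compound 4 gives a number. Also open, on these data alone, is whether a chain carrying a carboxylic acid or an amine in place of butyl would give a readable value in this assay.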